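Four amine tails on one shared core

A few compounds are considered here, and "the series" means these few. Any claim that something is new, unique, unknown or untested is made for them only; others in the source may bear on it.

Compound 1, `CCN1CCN(CCCOc2cc3nccc(Oc4c(F)cc(NC(=O)NN5C(=O)CSC5c5c(F)cccc5F)cc4F)c3cc2OC)CC1`, gives 3100 nM in a functional assay on MDA-MB-231 cells (Homo sapiens) for antiproliferative activity, read by MTT assay, with a stated time of 72 h; on this read-out lower numbers stand for stronger inhibition and higher numbers for weaker inhibition.
Compound 2, `COc1cc2c(Oc3c(F)cc(NC(=O)NN4C(=O)CSC4c4c(F)cccc4F)cc3F)ccnc2cc1OCCCN1CCC(C)CC1`, gives 3830 nM in this assay.
Compound 3, `COc1cc2c(Oc3c(F)cc(NC(=O)NN4C(=O)CSC4c4c(F)cccc4F)cc3F)ccnc2cc1OCCCN1CCN(C)CC1`, gives 4360 nM in this assay.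

Compound 3 holds the highest of the three numbers, yet its step from compound 2, a 1.1-fold higher number from compound 2 to compound 3 (0.06 log units; within the scatter), and from compound 1, a 1.4-fold higher number from compound 1 to compound 3 (0.15 log units; within the scatter), both lie inside the scatter, so the three compounds are not separated in this assay.

Compound 4, `CCN(CC)CCCOc1cc2nccc(Oc3c(F)cc(NC(=O)NN4C(=O)CSC4c4c(F)cccc4F)cc3F)c2cc1OC`, is not yet measured. It differs from compound 3 by diethylamino in place of 4-methylpiperazin-1-yl on a saturated chain carbon, three bonds along the chain from an oxygen on an aromatic ring. Within the data shown here, no measured pair makes exactly this exchange. Among the measured compounds shown here, the steps that bear on it all change the same amine at the same place: a 1.2-fold higher number from compound 1 to compound 2 (0.09 log units; within the scatter), a 1.4-fold higher number from compound 1 to compound 3 (0.15 log units; within the scatter) and a 1.1-fold higher number from compound 2 to compound 3 (0.06 log units; within the scatter), none of them beyond the scatter. On that basis the step to the open-chain amine is expected to be a 1.1-fold lower number from compound 3 to compound 4 (0.06 log units; within the scatter), with no direction beyond the scatter. Compound 4 is therefore estimated at 3800 nM in this assay, within a range of 1900 nM to 7600 nM.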

Compound 4, half-maximal inhibitory concentration: 3790 nM
The estimate for compound 4 lay 1.0-fold (0.00 log units) above the measured number, and the stated range covers the measured number.
By their numbers in this assay, from the lowest: compounds 1, 4, 2 and 3 (each within the scatter of the next).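

At this place, on a saturated chain carbon three bonds along the chain from an oxygen on an aromatic ring, compound 4 is the only one of the four with an open-chain amine; diethylamino has no ring and fewer heavy atoms than 4-methylpiperazin-1-yl. Opening the ring does not separate it from any ring amine in this assay: the result is a 1.2-fold lower number from compound 3 to compound 4 (0.06 log units; within the scatter) and a 1.0-fold lower number from compound 2 to compound 4 (0.00 log units; within the scatter) and a 1.2-fold higher number from compound 1 to compound 4 (0.09 log units; within the scatter), so across these four compounds neither the presence of a ring nor the kind of ring separates the numbers. Nothing measured here offers an explanation for this flat result.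

Still open, from the compounds shown here alone, is whether a morpholin-4-yl or pyrrolidin-1-yl group, or a smaller dimethylamino group, would stay level with these four at the same place. A longer chain carrying the same amines, or a chain ending in a hydroxyl group instead of an amine, also remains to be placed against them.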